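This account rests on a few compounds, and the source may have more. Where it says the series, first, only, none or still open, it means among the compounds named here.

Within the data shown here, in a functional assay on NCI-H1975 cells (Homo sapiens) for inhibition, with a stated time of 72 h (on this read-out lower numbers stand for stronger inhibition of growth and higher numbers for weaker inhibition of growth), compound 3 (`CC(C)c1cc(C(=O)N(C)Cc2ccc(C(=O)NO)cc2)c(O)cc1O`) gives 1700 nM and holds the lowest of the three numbers measured so far. Compound 1 (`COC(=O)c1ccc(CN(C)C(=O)c2cc(C(C)C)c(O)cc2O)cc1`) gives 3500 nM in this assay and compound 2 (`CCN(Cc1ccc(C(=O)NO)cc1)C(=O)c1cc(Cl)c(O)cc1O`) gives 13200 nM in this assay and both lie higher, beyond the scatter. Compound 4 (`CCN(Cc1ccc(C(=O)NO)cc1)C(=O)c1cc(C(C)C)c(O)cc1O`) has not yet been measured. It departs from compound 3 by methyl in place of hydrogen on a saturated chain carbon bound to an amide-type nitrogen and this is methyl in place of hydrogen on a saturated chain carbon bound to an amide-type nitrogen, so that methyl becomes ethyl. Among the measured compounds shown here, the only measured step, a 2.1-fold lower number from compound 1 to compound 3 (0.31 log units; beyond the scatter) in size, is modest and lies elsewhere in the structure, as hydroxyamino in place of methoxy on a carbonyl carbon. It therefore says nothing direct about this change. For the measured compounds named here, compound 2 shares the ethyl with compound 4 but bears a chlorine in place of the isopropyl, so it offers no measured step for this change either. As far as these compounds go, with no measured evidence at this place, no shift beyond the scatter is expected in this assay and the direction stays open. The expected step is a 1.1-fold lower number from compound 3 to compound 4 (0.05 log units; within the scatter) and it remains within the scatter. For compound 4 the estimated value is 1500 nM with an expected range from 600 nM to 3800 nM in all.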

Compound 4, concentration for 50% growth inhibition: 7000 nM
Compound 4: middle estimate off by 4.7-fold (0.67 log units), on the low side; measured number above the stated range.
By their numbers in this assay, from the lowest: compound 3; then compounds 1, 4 and 2 (each within the scatter of the next, the first and the last beyond it).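

Among these compounds, the methyl-to-ethyl change is the first measured change at this place, and in this assay it gives a 4.1-fold higher number from compound 3 to compound 4 (0.61 log units; beyond the scatter). So with the isopropyl in place, the group on the amide-type nitrogen does affect the read-out, and the extra carbon moves the number in the unfavourable direction, a larger shift than the one seen earlier at the carbonyl carbon. With the ethyl held constant, isopropyl in place of chloro on an aromatic carbon gives a 1.9-fold lower number from compound 2 to compound 4 (0.28 log units; within the scatter), so this pair shows no difference between those two groups, although the step stays close to the edge of the scatter. Nothing at hand accounts for the shift at the amide-type nitrogen.

Whether the methyl-to-ethyl step would have the same size with chloro in place of the isopropyl stays open, since the compounds shown offer only this one step at that place. As far as these compounds go, it is also open whether the number would keep rising along a longer chain such as propyl, or how a chain ending in an amine would read at this nitrogen.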